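Swapping Bromo for Trifluoromethyl on the Shared Core

The source may report more compounds than this note shows. Statements on the series, on what has been measured and on what is new or still open speak of the compounds shown alone.

Of the compounds shown here, three built on one shared core have been tested in a functional assay on the whole organism with Mus musculus as the target, in the writhing test; on this read-out higher numbers stand for an effect only at larger amounts of compound and lower numbers for an effect already at smaller amounts. Compound 1 `Clc1ccc2[nH]cc(SC3CCNCC3)c2c1` gives 0.3 mg/kg. Compound 2 `CCOC(=O)N1CCC(Sc2c[nH]c3ccc(Br)cc23)CC1`, which carries an ethyl carbamate on its piperidine nitrogen, gives 6.3 mg/kg. Compound 3 `Cc1[nH]c2ccc(Br)cc2c1SC1CCNCC1` gives 0.7 mg/kg, the second highest of the three numbers: compound 1 stands nearest with a lower number, beyond the scatter, and compound 2 stands furthest away with a higher number, also beyond the scatter.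

Compound 4 `Cc1[nH]c2ccc(C(F)(F)F)cc2c1SC1CCNCC1` has not yet been measured. It differs from compound 3 in one place: trifluoromethyl in place of bromo on an aromatic carbon. Among the compounds with values here, no measured pair differs only in this way, so the size of such a step cannot be read from the data at hand. Bromo and trifluoromethyl are both small uncharged groups without donors or acceptors, so the expected step of a 1.4-fold higher number from compound 3 to compound 4 (0.15 log units; within the scatter) is one that stays within the usual scatter, in no clear direction. Compound 4 is therefore expected to give about 1 mg/kg in this assay, with a likely range from 0.3 mg/kg to 3 mg/kg.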

Compound 4, dose for half-maximal effect: 19.4 mg/kg
The estimate for compound 4 lay 19-fold (1.29 log units) below the measured number; the whole stated range lies below it.
By their numbers in this assay, from the lowest: compound 1; then compound 3; then compound 2; then compound 4.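

In this assay, within the data shown here, the aromatic carbon that carries the bromo group in compound 3 proves sensitive to what sits there: trifluoromethyl in place of bromo gives a 28-fold higher number from compound 3 to compound 4 (1.44 log units; beyond the scatter) and is the only change at this place that can be read here. The two groups match in having no ring, no hydrogen-bond donors or acceptors and no net charge, so those shared counts do not ensure a similar number at this place. Nothing available here accounts for the size of this step.

On these data alone, whether a methoxy group, a nitrile or an amine at this place would stay close to compound 3 or move as far as compound 4 remains open. As far as these compounds go, it is also open whether trifluoromethyl would give a similar step on the core of compound 1 or alongside the ethyl carbamate of compound 2.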